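The source may report more compounds than this note shows. Statements on the series, on what has been measured and on what is new or still open speak of the compounds shown alone.

Measured so far in an ADME assay on microsomes (Homo sapiens) for metabolic stability; on this read-out higher numbers stand for fast clearance and lower numbers for slow clearance:
- compound 1 `CNC(=O)[C@@H]1CCCN1S(=O)(=O)c1ccc(Cl)c(COc2cccc3c(-n4ccnc4)cc(C)nc23)c1Cl` gives 33.3 mL/min/kg
- compound 2 `Cc1cc(C(F)(F)F)c2cccc(OCc3c(Cl)ccc(S(=O)(=O)N4CCCCC4)c3Cl)c2n1` gives 233 mL/min/kg
- compound 3 `Cc1cc(C(F)(F)F)c2cccc(OCc3c(Cl)ccc(S(=O)(=O)N4C[C@@H](C)O[C@@H](C)C4)c3Cl)c2n1` gives 317 mL/min/kg

Compound 1 has the lowest number of the three, and its gap to each of the other two lies beyond the scatter. Compound 4 `CNC(=O)[C@@H]1CCCN1S(=O)(=O)c1ccc(Cl)c(COc2cccc3c(-c4ccncc4)cc(C)nc23)c1Cl` keeps everything in compound 1 except one group. It has pyridin-4-yl in place of 1H-imidazol-1-yl on an aromatic carbon, opposite the ring nitrogen: pyridin-4-yl in place of 1H-imidazol-1-yl on an aromatic carbon.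

Among the compounds with values here, only one measured step is available, a 1.4-fold higher number from compound 2 to compound 3 (0.13 log units; within the scatter). It lies within the scatter, but it is a change on a sulfonyl sulfur, so it offers only weak guidance for this swap. Compound 2 and compound 3 also differ from compound 1 in more than one place, so their higher numbers cannot be tied to any single group. Within the data shown here, no measured step touches this position, so no step beyond the scatter is expected, and the estimated change is a 1.4-fold higher number from compound 1 to compound 4 (0.13 log units; within the scatter). For compound 4 the estimated clearance is 45 mL/min/kg, with an expected range of 18 mL/min/kg to 110 mL/min/kg.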

Compound 4, clearance: 217 mL/min/kg
For compound 4 the middle estimate is 4.8-fold (0.68 log units) below the measured one; measured number above the stated range.
By their numbers in this assay, from the lowest: compound 1; then compounds 4, 2 and 3 (each within the scatter of the next).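

Within the data shown here, this is the first measured change at the place opposite the ring nitrogen, and it shows that clearance is sensitive to the group there. In this assay, exchanging 1H-imidazol-1-yl for pyridin-4-yl gives a 6.5-fold higher number from compound 1 to compound 4 (0.81 log units; beyond the scatter) with everything else in the molecule held the same. Both groups are uncharged aromatic rings without hydrogen-bond donors, so sharing those counted features did not keep the number low. Nothing measured here explains why the number rises.

Going by these compounds, it remains open whether the low value of compound 1 is specific to 1H-imidazol-1-yl or would also appear with another ring there, such as 1H-pyrazol-1-yl or pyridin-3-yl. It is also unclear whether the step would keep its size with piperidin-1-yl on the sulfonyl sulfur.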